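The source may hold more compounds than are shown below. What is called first, only, known or untested is meant among the compounds shown, and "the series" means these compounds.

Measured in a functional assay on HT-29 cells (Homo sapiens) for inhibition, read by sulforhodamine B assay, with a stated time of 48 h; a higher number here means a weaker inhibitor of growth, a lower number a stronger inhibitor of growth:
Compound 1 `CCOC(=O)c1nn(-c2ccccc2)c(-c2ccc(Cl)cc2)c1CNC(C)(C)C`: 58500 nM; > 559000 nM (2 entries)
Compound 2 `CC(C)(C)NCc1c(C(=O)O)nn(-c2ccccc2)c1-c1ccc(Cl)cc1`: 353000 nM

Compound 1 has several entries, and one of them is a limit of the assay and not a number: the several entries of compound 1 in this assay, 58500 nM; > 559000 nM (2 entries). Among the compounds with values here, compound 2 gives 353000 nM, the only single number in this small set, so there is no firm value to rank it against.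

Compound 3 `COc1ccc(-c2c(CNC(C)(C)C)c(C(=O)O)nn2-c2ccccc2)cc1` keeps the rest of compound 2 and changes one group, from 4-chlorophenyl to 4-methoxyphenyl: methoxy in place of chloro on an aromatic carbon. Within the data shown here, no measured pair shows what this swap does, so no step beyond the scatter is expected in this assay, in either direction. The expected change is small: a 1.2-fold lower number from compound 2 to compound 3 (0.07 log units; within the scatter). This expectation starts from compound 2 at 353000 nM. Compound 3 is estimated at 300000 nM, with an expected range of 120000 nM to 700000 nM.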

Compound 3, concentration for 50% growth inhibition: > 659000 nM
Compound 3 ended at the assay's limit; the forecaster's own chance of this, stated with the estimate: 30%; middle value at least 2.1-fold (0.34 log units) from the limit.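

In this assay, compound 3 gives > 659000 nM, which is a limit of the assay and not a number. Within the data shown here, this is the only measured pair for methoxy in place of chloro on this aromatic carbon, para to a large group, and it can be read in one direction only: an at least 1.8-fold higher number from compound 2 to compound 3 (0.27 log units; that floor lies within the scatter). From the compounds shown here alone, the swap therefore brings no lower number, but the floor alone does not separate the two compounds, and the true size of the step remains unknown.

Going by these compounds, it remains open how an amine or a nitrile on the same aromatic carbon would read in this assay. Also open, on these data alone, is whether the swap would give the same result with the ethyl ester of compound 1 in place of the carboxylic acid.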